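The compounds below may be only part of what the source reports. "The series", "measured", "known", "first", "only" and "open" are said of these compounds alone.

Measured so far in an assay on isolated protein for inhibition of histone deacetylase 4 (Homo sapiens), with a stated time of 1 h; on this read-out lower numbers stand for stronger inhibition and higher numbers for weaker inhibition:
compound 1 `O=C(COc1ccc2cc(/C=C3/SC(=O)NC3=O)ccc2c1)Nc1cccc(C(F)(F)F)c1` gives 2500 nM
compound 2 `Cc1cccc(NC(=O)COc2ccc3cc(/C=C4/SC(=O)NC4=O)ccc3c2)n1` gives 1100 nM

For the measured compounds named here, compound 2 holds the lowest of the two numbers in this assay; the only other point is compound 1. Going by the values given here, the one known step, a 2.3-fold lower number from compound 1 to compound 2 (0.36 log units; beyond the scatter), is a swap of the aryl group on the amide-type nitrogen. Among the compounds with values here, compound 3 `Cc1cc(NC(=O)COc2ccc3cc(/C=C4/SC(=O)NC4=O)ccc3c2)no1` carries a further such swap, (5-methyl-1,2-oxazol-3-yl in place of 6-methylpyridin-2-yl on an amide-type nitrogen), for which no measured step bears directly. Given that the single aryl swap seen moved the number only modestly, a change within or just beyond the scatter is expected, direction uncertain. Compound 3 is therefore estimated at 1500 nM, range 500 nM to 4500 nM, meaning a step of a 1.4-fold higher number from compound 2 to compound 3 (0.13 log units; within the scatter).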

Compound 3, half-maximal inhibitory concentration: 1700 nM
Estimate against measurement, compound 3: 1.1-fold (0.05 log units) below; low and high end bracket the measured number.
By their numbers in this assay, from the lowest: compounds 2, 3 and 1 (each within the scatter of the next, the first and the last beyond it).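

In this assay the amide-type nitrogen accepts a five-membered aromatic ring with 2 hetero atoms in place of a six-membered one, giving a 1.5-fold higher number from compound 2 to compound 3 (0.19 log units; within the scatter) and, against the 3-(trifluoromethyl)phenyl group, a 1.5-fold lower number from compound 1 to compound 3 (0.17 log units; within the scatter). Compound 3 therefore cannot be separated from either compound 2 or compound 1, although those two are separated from each other. No supporting data bear on these readings.

From the compounds shown here alone, whether any group at this position moves the number well outside this narrow band stays open. A carboxylic acid, an amine or a longer chain in place of the methyl remains untested in the compounds shown.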